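A Fluorine Added to the Aromatic Ring of Compound 2

The compounds below may be only part of what the source reports. "The series", "measured", "known", "first", "only" and "open" are said of these compounds alone.

Of the compounds shown here, two have been measured in an assay on isolated protein for inhibition of proto-oncogene tyrosine-protein kinase receptor Ret variant V804M (Homo sapiens), read by 33P incorporation, with stated times of 15 min and 40 min; a lower number here means a stronger inhibitor, a higher number a weaker inhibitor. Compound 1, `O=C(Nc1ccc(Cl)cc1)Nc1ccc(Nc2ncnc3c2OCCN3)cc1`, gives 2280 nM. Compound 2, `CC(C)(C)c1cc(NC(=O)Nc2ccc(Nc3ncnc4c3OCCN4)cc2)no1`, gives 34 nM. Among the measured compounds shown here, the one step between them, a 67-fold lower number from compound 1 to compound 2 (1.83 log units; beyond the scatter), exchanges the group on the amide-type nitrogen and leaves the rest of the shared core untouched. For the measured compounds named here, compound 2 therefore stands at the lowest of the two numbers, and its only neighbour, compound 1, sits at a higher number by that large step.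

Compound 3, `CC(C)(C)c1cc(NC(=O)Nc2ccc(Nc3ncnc4c3OCCN4)cc2F)no1`, keeps everything of compound 2 and changes a single place: fluoro in place of hydrogen on an aromatic carbon. The measured step from compound 1 to compound 2 concerns a different part of the molecule, the group attached to the amide-type nitrogen, and says nothing about a substituent on a six-membered aromatic ring. Going by the values given here, no measured pair isolates this kind of change, so there is no step to lean on. The expectation is therefore a step of a 1.1-fold lower number from compound 2 to compound 3 (0.05 log units; within the scatter), which is to say none beyond the scatter, in either direction. Compound 3 is expected to give 30 nM in this assay, with a range from 10 nM to 90 nM.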

Compound 3, half-maximal inhibitory concentration: 57 nM
Compound 3: middle estimate off by 1.9-fold (0.28 log units), on the low side; the measured number falls inside the stated range.
By their numbers in this assay, from the lowest: compounds 2 and 3 (each within the scatter of the next); then compound 1.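

Among the compounds shown here, this is the first reading of a change on the six-membered aromatic ring of carbon only: fluoro in place of hydrogen, on a carbon ortho to a large group and meta to a large group. In this assay, the result is a 1.7-fold higher number from compound 2 to compound 3 (0.22 log units; within the scatter), so this single fluorine atom leaves compound 3 indistinguishable from compound 2, and this carbon can carry fluoro without a measurable loss or gain. That small step contrasts with the exchange on the amide-type nitrogen, a 67-fold lower number from compound 1 to compound 2 (1.83 log units; beyond the scatter), and no measurement available here offers an explanation for the result.

The compounds shown leave open whether chloro, methyl or methoxy on this same aromatic carbon would also stay within the scatter of compound 2, and whether fluoro on another carbon of this ring would read the same. They also leave open whether fluoro at this place would give a similarly small step with 4-chlorophenyl on the amide-type nitrogen, as in compound 1, in place of the 5-(tert-butyl)-1,2-oxazol-3-yl group.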